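A few compounds are considered here, and "the series" means these few. Any claim that something is new, unique, unknown or untested is made for them only; others in the source may bear on it.

Of the compounds shown here, three have been measured in an assay on HEK293 cells for negative allosteric modulation of metabotropic glutamate receptor 5 (Homo sapiens), read by FLIPR, with a stated time of 1 h (a higher number here means a weaker inhibitor, a lower number a stronger inhibitor), and one more awaits a number. Compound 1 `O=C1NCCc2nc(C#Cc3ccccc3)sc21` reaches only the limit of the assay, giving > 10000 nM in this assay; this is a limit, not a number. Compound 2 `CN1CCc2nc(C#Cc3cccc(F)c3)sc2C1` also stops at a limit, with > 10000 nM in this assay. Among the measured compounds shown here, compound 3 `CC(C)CN1CCc2nc(C#Cc3ccccc3)sc2C1` is the only one with an actual value, giving 650 nM in this assay, so it stands as the one measured number, with the two other compounds sitting at the limit of > 10000 nM in this assay, at which 2 of the 3 values shown sit.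

The compound not yet measured is compound 4 `CC(C)S(=O)(=O)N1CCc2nc(C#Cc3ccccc3)sc2C1`. Compared with compound 3, the change is isopropylsulfonyl in place of isobutyl on an amine nitrogen in a ring. For the measured compounds named here, there is no measured pair in this set that differs in a single place, so no step can be read off directly; the only guide is that compound 3, which carries the isobutyl group, gives a number while compound 1 and compound 2 do not.

Compound 4 is therefore expected to lie toward weaker inhibition, with the step of a 3.8-fold higher number from compound 3 to compound 4 (0.59 log units; beyond the scatter) being the estimate, and a fair chance that only a limit is reported. For compound 4 the estimated value in this assay is 2500 nM, within a range of 400 nM to 10000 nM.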

Compound 4, half-maximal inhibitory concentration: 11 nM
Beside the measured number, compound 4's estimate is 230-fold (2.36 log units) above it; the measured number lies below the stated range.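

In this assay, the substituent on the amine nitrogen in the ring has a large effect: isopropylsulfonyl in place of isobutyl gives a 59-fold lower number from compound 3 to compound 4 (1.77 log units; beyond the scatter). Among the compounds shown here, this is the first comparison in the set between compounds that differ in a single place, and it shows that this nitrogen need not carry a simple hydrocarbon group such as isobutyl, since a group containing sulfur and oxygen, with two hydrogen-bond acceptors where isobutyl has none, goes with much stronger inhibition. This one pair cannot show which part of the change matters, as the entering group differs from the leaving one in its atoms, its size and its acceptors all at once.

An amide, an ethylsulfonyl group or a cyclopropylsulfonyl group on the same nitrogen would help show whether the lower number goes with the sulfonyl link itself or with the isopropyl part attached to it. Neither of the other compounds offers a number to set beside this step, only a limit of the assay: the limit of > 10000 nM in this assay, at which 2 of the 4 values shown sit.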